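Removing a Hydroxy Group From a Dichlorophenoxy Propanol Series

This account rests on a few compounds, and the source may have more. Where it says the series, first, only, none or still open, it means among the compounds named here.

Of the compounds shown here, three have been measured in a physicochemical assay for lipophilicity, measured as octanol-water partition; a higher number here means a more lipophilic compound, a lower number a more polar compound. Compound 1 `CC(O)COc1ccc(Cl)cc1Cl` gives 2.75 in this assay. Compound 2 `OCC(O)COc1ccc(Cl)cc1Cl` carries one hydroxy group more on its chain, and in this assay compound 2 gives 1.99. Compound 3 `Cc1cc(Cl)c(OCC(O)CO)c(Cl)c1` has the same chain as compound 2 on a core that carries an added methyl group; in this assay compound 3 gives 2.4, which places it between the other two, with a gap to each that is beyond the scatter. The difference between the cores of compound 2 and compound 3 is not broken down here.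

The measured pair shows what one change does: from compound 2 to compound 1 the change is hydrogen in place of hydroxy on a saturated chain carbon, two bonds along the chain from an oxygen on a saturated carbon, and the step is a number 0.76 log units higher from compound 2 to compound 1 (beyond the scatter).

Compound 4 `Cc1cc(Cl)c(OCC(C)O)c(Cl)c1` has not been measured. The change from compound 3 to compound 4 is hydrogen in place of hydroxy on a saturated chain carbon, two bonds along the chain from an oxygen on a saturated carbon. This is the same change as from compound 2 to compound 1, made on the same place of the chain, so the expectation rests on that measured step. The step from compound 3 to compound 4 in this assay is expected to be a number 0.76 log units higher from compound 3 to compound 4 (beyond the scatter), about the size of the earlier one, because the earlier change gave a number 0.76 log units higher from compound 2 to compound 1 (beyond the scatter). Compound 4 is therefore estimated to give 3.16 in this assay, most likely between 2.8 and 3.5.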

Compound 4, partition coefficient: 3.16
The estimate for compound 4 equals the measured number at the digits printed; low and high end bracket the measured number.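

In this assay the change from 2,3-dihydroxypropyl to 2-hydroxypropyl gives a number 0.76 log units higher from compound 3 to compound 4 (beyond the scatter) and, on the other core, gives a number 0.76 log units higher from compound 2 to compound 1 (beyond the scatter) so the step has the same size on both cores at the digits printed. This shows that, for these two matched pairs, the effect of replacing the hydroxy with hydrogen at this place on the chain carries over from one core to the other, and the core of compound 3 does not alter the size of the step. Among these compounds, it rests on only two pairs, however, so it does not establish a rule for other cores, and no available data bear on why the two steps match.

The compounds shown leave open whether a step of this size would appear if an amine or a carboxylic acid stood in place of the hydroxy, since every change here is from hydroxy to hydrogen. They also leave open whether the match would survive on a longer chain, where the hydroxy would stand further from the core.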